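Adding a Chloro Group to Compound 1

The compounds below may be only part of what the source reports. "The series", "measured", "known", "first", "only" and "open" are said of these compounds alone.

For the measured compounds named here, in a functional assay on RPMI8266 cells (Homo sapiens) for inhibition (on this read-out higher numbers stand for weaker inhibition of growth and lower numbers for stronger inhibition of growth), compound 1 (`COc1cc(/C=C/C(=O)c2cccc(-n3cc(-c4ccccc4)[nH]c3=O)c2)ccc1O`) gives 1670 nM, the higher of the two numbers so far, while compound 2 (`COc1cc(/C=C/C(=O)c2cccc(-n3cc(-c4cc(OC)c(OC)c(OC)c4)[nH]c3=O)c2)cc(OC)c1OC`) gives 230 nM. Compound 3 (`COc1cc(/C=C/C(=O)c2cccc(-n3cc(-c4ccc(Cl)cc4)[nH]c3=O)c2)ccc1O`) has chloro in place of hydrogen on an aromatic carbon, turning phenyl to 4-chlorophenyl: chloro in place of hydrogen on an aromatic carbon. Going by the values given here, no measured pair shows this change, so the expectation is uncertain: a small step in this assay, perhaps no larger than the scatter, leaning toward a lower number. The expected change is a 1.7-fold lower number from compound 1 to compound 3 (0.22 log units; within the scatter). For compound 3, the estimated value is 1000 nM, with an expected range of 400 nM to 2500 nM.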

Compound 3, concentration for 50% growth inhibition: 1330 nM
The estimate for compound 3 lay 1.3-fold (0.12 log units) below the measured number; measured number inside the range.
By their numbers in this assay, from the lowest: compound 2; then compounds 3 and 1 (each within the scatter of the next).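

In this assay, this single-place change reads a 1.3-fold lower number from compound 1 to compound 3 (0.10 log units; within the scatter) and so stays within the usual scatter of repeated measurements. At this position, para to a large group, the phenyl of compound 1 therefore takes chloro in place of hydrogen with no clear shift in this read-out. Nothing measured here offers an explanation for this result.

On these data alone, one small atom at one position is only a single probe, so it remains open whether an amine or a carboxylic acid there would also leave the number within the scatter.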